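Toxicity notes on an allyl amide series with a para substituent

The compounds below may be only part of what the source reports. "The series", "measured", "known", "first", "only" and "open" are said of these compounds alone.

Measured so far in a toxicity assay on the whole organism (strain Icem-CET (SPF Caw)) for cytotoxicity, with Mus musculus as the target; a higher number here means that more compound is needed for the effect, a lower number that less compound is needed:
compound 1, `C=CCNC(=O)/C(C)=C(/C)c1ccc(Cl)cc1`, gives 400 mg/kg
compound 2, `C=CCNC(=O)/C(C)=C(/C)c1ccccc1`, gives 400 mg/kg
compound 3, `C=CCNC(=O)/C(C)=C(\C)c1ccc(Cl)cc1`, gives 70 mg/kg

Compound 4, `C=CCNC(=O)/C(C)=C(\C)c1ccccc1`, is not yet measured.

Two changes run through the set. Between compound 1 and compound 2 the change is hydrogen in place of chloro on an aromatic carbon; the step in this assay is no change at the digits printed from compound 1 to compound 2 (within the scatter). Between compound 1 and compound 3 the change is the two compounds have the same atoms and bonds and differ only in configuration as drawn: 1 of 1 stereo elements differ; a double bond is drawn Z in compound 1 and E in compound 3; here the step is a 5.7-fold lower number from compound 1 to compound 3 (0.76 log units; beyond the scatter), and the only difference that can be pointed to is the fact that compounds 1 and 3 differ only in the configuration as drawn.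

Compound 4 stands to compound 3 as compound 2 stands to compound 1: the change is hydrogen in place of chloro on an aromatic carbon, the same change as before, made on the core of compound 3 rather than on the core of compound 1. The two cores differ by the two compounds have the same atoms and bonds and differ only in configuration as drawn: 1 of 1 stereo elements differ; a double bond is drawn Z in compound 1 and E in compound 3.

Going by the values given here, since the first instance of this change, no change at the digits printed from compound 1 to compound 2 (within the scatter), stayed within the scatter, the step from compound 3 to compound 4 is expected to be no change at the digits printed from compound 3 to compound 4 (within the scatter). Compound 4 is therefore estimated at 70 mg/kg, with a likely range from 35 mg/kg to 140 mg/kg.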

Compound 4, dose for half-maximal effect: 250 mg/kg
Compound 4: middle estimate off by 3.6-fold (0.55 log units), on the low side, outside the stated range (above it).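

In this assay, hydrogen in place of chloro on the core of compound 3 gives a 3.6-fold higher number from compound 3 to compound 4 (0.55 log units; beyond the scatter), so this change does not carry over unaltered from the core of compound 1: the same change on two cores in this assay, no change at the digits printed (within the scatter) from compound 1 to compound 2 and a 3.6-fold higher number (0.55 log units; beyond the scatter) from compound 3 to compound 4, 3.6-fold (0.55 log units) apart, beyond the scatter of two such steps. On the hydrogen-bearing pair, the change of configuration gives a 1.6-fold lower number from compound 2 to compound 4 (0.20 log units; within the scatter), whereas on the chloro pair it gave a 5.7-fold lower number from compound 1 to compound 3 (0.76 log units; beyond the scatter), so the two cores cannot be treated as interchangeable for this change: the fact that compounds 2 and 4 differ only in the configuration as drawn. This shows that the effect of removing chloro depends on the core in this one pair of cores, but it does not give the reason for that dependence or show how the change would behave on any other core.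

The compounds shown leave open whether bromo or methoxy in place of chloro would follow the same dependence on configuration. They also leave open whether a longer chain in place of the allyl group would keep the gap between the two cores.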